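Dimethoxyphenyl replacing methylphenyl on the shared amide series

The source may hold more compounds than are shown below. What is called first, only, known or untested is meant among the compounds shown, and "the series" means these compounds.

Measured compounds:
Compound 1, `COc1cc2c(Oc3ccc(NC(=O)c4cc(-c5ccc(F)cc5)ccn4)cc3F)ccnc2cc1OCCCN1CCCCC1`, in a functional assay on HT-29 cells (Homo sapiens) for cytotoxicity, read by MTT assay, with a stated time of 72 h (on this read-out lower numbers stand for stronger inhibition and higher numbers for weaker inhibition), gives 1370 nM.
Compound 2, `COc1cc2c(Oc3ccc(NC(=O)c4cc(-c5ccccc5F)ccn4)cc3F)ccnc2cc1OCCCN1CCN(C)CC1`, in this assay gives 220 nM.
Compound 3, `COc1cc2c(Oc3ccc(NC(=O)c4cc(-c5ccc(C)cc5)ccn4)cc3F)ccnc2cc1OCCCN1CCCC1`, in this assay gives 350 nM.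

Among the three numbers in this assay, compound 3 stands second highest. Its nearest neighbour is compound 2, and the gap between them lies within the scatter of repeated measurements, so no order between the two can be read. Compound 1 is the furthest, with a higher number than compound 3 by a gap beyond the scatter.

Compound 4, `COc1ccc(-c2ccnc(C(=O)Nc3ccc(Oc4ccnc5cc(OCCCN6CCCC6)c(OC)cc45)c(F)c3)c2)c(OC)c1`, is not yet measured. Relative to compound 3 the change is 2,4-dimethoxyphenyl in place of 4-methylphenyl on an aromatic carbon. Among the compounds with values here, no step between measured compounds with the same kind of change is available, so the expected effect rests on the spread of the three values alone. In this assay no step beyond the scatter is expected in either direction, though the direction itself is uncertain.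

Compound 4 is expected to give 400 nM, with a range from 150 nM to 1200 nM. That estimate corresponds to an expected step of a 1.1-fold higher number from compound 3 to compound 4 (0.06 log units; within the scatter).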

Compound 4, half-maximal inhibitory concentration: 630 nM
The estimate for compound 4 lay 1.6-fold (0.20 log units) below the measured number, and the stated range covers the measured number.
By their numbers in this assay, from the lowest: compounds 2, 3 and 4 (each within the scatter of the next, the first and the last beyond it); then compound 1.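

In this assay, 2,4-dimethoxyphenyl in place of 4-methylphenyl, at the place opposite the ring nitrogen, gives a 1.8-fold higher number from compound 3 to compound 4 (0.26 log units; within the scatter). Within the data shown here, this is the first comparison that differs in one place only, and it shows that this position accepts a larger group, with 10 heavy atoms against 7 and 2 hydrogen-bond acceptors against 0, without a step beyond the scatter. No independent data bear on why the two groups read alike in this cell assay.

Open, from the compounds shown here alone, is whether a phenyl carrying a single methoxy, an amine or a carboxylic acid would also stay within the scatter of compound 3. Compounds 1 and 2 differ from compound 3 in more than one place, so the fluorophenyl groups they carry cannot yet be set against this step.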